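Compound 3: replacing the 4-nitrophenyl group

The source may hold more compounds than are shown below. What is called first, only, known or untested is meant among the compounds shown, and "the series" means these compounds.

In a functional assay on ECV-304 cells (Homo sapiens) for cytotoxicity (a lower number here means a stronger inhibitor, a higher number a weaker inhibitor), compound 2 (`O=C1/C(=C/c2ccc([N+](=O)[O-])cc2)SC(=S)N1NS(=O)(=O)c1ccccc1`) gives > 50000 nM as a limit and not a number. Compound 1 (`Cc1ccc(S(=O)(=O)NN2C(=S)S/C(=C\c3ccc(Cl)c(Cl)c3)C2O)cc1`) gives > 50000 nM as a limit too. Compound 3 (`O=C1/C(=C/c2cc(F)ccc2F)SC(=S)N1NS(=O)(=O)c1ccccc1`) has 2,5-difluorophenyl in place of 4-nitrophenyl on a double-bonded chain carbon bound to a double-bonded ring carbon. Within the data shown here, no measured step is available, and the expectation for compound 3 rests only on the limit of > 50000 nM in this assay, at which 2 of the 2 values shown sit, as its evidence. The expected at least 1.2-fold lower number from compound 2 to compound 3 (0.09 log units; that floor lies within the scatter) is estimated to stay within the scatter, with no direction favoured. For compound 3 the estimated value is 40000 nM with an expected range from 15000 nM to 100000 nM in this measurement.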

Compound 3, half-maximal inhibitory concentration: > 50000 nM
Compound 3: only a limit was reported; the forecaster's own chance of this, stated with the estimate: 70%; middle value at least 1.2-fold (0.09 log units) from the limit.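

Compound 2 and compound 3 are both reported only as limits in this assay, and no step can be read between them. The compounds shown leave open how 2,5-difluorophenyl and 4-nitrophenyl compare on the shared core.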